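Notes on amide-nitrogen substituent changes in a lipopeptide series

The source may hold more compounds than are shown below. What is called first, only, known or untested is meant among the compounds shown, and "the series" means these compounds.

Compound 1 `CCCCCCCCCCCC(=O)OC[C@H](CSC[C@@H](N)C(=O)NCCO)OC(=O)CCCCCCCCCCC` carries a 2-hydroxyethyl group on the amide-type nitrogen. In an assay on HEK293 cells for agonist activity at Toll-like receptor 2 (Homo sapiens) (a lower number here means that less compound is needed, a higher number that more compound is needed for the effect), compound 1 gives 24 nM, the lowest number among the three measured compounds. Compound 2 `CCCCCCCCCCCC(=O)OC[C@H](CSC[C@@H](N)C(=O)N[C@@H](CC)COCC(=O)O)OC(=O)CCCCCCCCCCC` gives 6500 nM in this assay, and compound 3 `CCCCCCCCCCCC(=O)OC[C@H](CSC[C@@H](N)C(=O)NCCN)OC(=O)CCCCCCCCCCC` gives 5240 nM. Changing the substituent on the amide-type nitrogen away from 2-hydroxyethyl has so far cost heavily: a 270-fold higher number from compound 1 to compound 2 (2.43 log units; beyond the scatter). Between the two weaker compounds a 1.2-fold lower number from compound 2 to compound 3 (0.09 log units; within the scatter).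

Compound 4 `CCCCCCCCCCCC(=O)OC[C@H](CSC[C@@H](N)C(=O)NCCCCN)OC(=O)CCCCCCCCCCC` is not yet measured. Against compound 1 the change is 2-aminoethyl in place of hydroxy on a saturated chain carbon, two bonds along the chain from an amide-type nitrogen. Among the measured compounds shown here, the measured step that bears on this is the one from compound 1 to compound 3, where an amino replaced the hydroxy at the same place: a 220-fold higher number from compound 1 to compound 3 (2.34 log units; beyond the scatter). The change toward compound 4 likewise exchanges the hydroxy for a nitrogen-bearing group at that place, only with a longer chain. For the measured compounds named here, no measured pair shows the effect of the extra chain length alone, so the expectation rests on compound 3 and is a large rise in this assay, of roughly the same size. Compound 4 is therefore expected to give about 3000 nM, with a range from 500 nM to 20000 nM. This corresponds to an expected step of a 130-fold higher number from compound 1 to compound 4 (2.10 log units; beyond the scatter).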

Compound 4, half-maximal effective concentration: 1040 nM
Estimate against measurement, compound 4: 2.9-fold (0.46 log units) above; measured number inside the range.
By their numbers in this assay, from the lowest: compound 1; then compound 4; then compounds 3 and 2 (each within the scatter of the next).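

In this assay, the two amine-ended substituents on the amide-type nitrogen are not interchangeable: 2-aminoethyl in place of amino on the saturated chain carbon gives a 5.0-fold lower number from compound 3 to compound 4 (0.70 log units; beyond the scatter), so chain length matters at this place once the end group is an amine. The 4-aminobutyl group also separates from the 1-((carboxymethoxy)methyl)propyl group, with a 6.3-fold lower number from compound 2 to compound 4 (0.80 log units; beyond the scatter), whereas compound 3 and compound 2 stay within the scatter of each other. The longer chain recovers only part of the loss, however, leaving a 43-fold higher number from compound 1 to compound 4 (1.64 log units; beyond the scatter), and the 2-hydroxyethyl group of compound 1 still gives the lowest number of the four.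

The compounds shown leave open whether a longer amine such as 6-aminohexyl would lower the number further, and whether a longer chain ending in hydroxy, such as 4-hydroxybutyl, would hold the level of compound 1 or shift it. Nothing available accounts for the gain from the longer amine chain or for the remaining gap to the hydroxy-ended compound.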